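Shortening an alkoxy chain on a purine-like core

The source may report more compounds than this note shows. Statements on the series, on what has been measured and on what is new or still open speak of the compounds shown alone.

Compounds measured so far, with their dose in a functional assay on the whole organism for activation, with Mus musculus as the target; on this read-out lower numbers stand for an effect already at smaller amounts and higher numbers for an effect only at larger amounts of compound:
- compound 1, `CCCSc1nc(N)c2nc(O)n(Cc3ccccc3)c2n1`, 0.1 mg/kg
- compound 2, `CCOc1nc(N)c2nc(O)n(Cc3ccccc3)c2n1`, 0.3 mg/kg
- compound 3, `CCCc1nc(N)c2nc(O)n(Cc3ccccc3)c2n1`, 3 mg/kg

Compound 3 needs the largest dose of the three: the steps leading to it are a 10-fold higher number from compound 2 to compound 3 (1.00 log units; beyond the scatter) and a 30-fold higher number from compound 1 to compound 3 (1.48 log units; beyond the scatter), both beyond the scatter. The next compound is compound 4, `COc1nc(N)c2nc(O)n(Cc3ccccc3)c2n1`. It differs from compound 3 in one place: methoxy in place of propyl on an aromatic carbon.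

Among the compounds with values here, one measured step bears directly on this change. From compound 2 to compound 3, propyl replaced ethoxy, and the dose rose: a 10-fold higher number from compound 2 to compound 3 (1.00 log units; beyond the scatter). Compound 4 reverses that kind of change, swapping propyl for a shorter alkoxy group, methoxy. Within the data shown here, no measured pair shows what shortening ethoxy to methoxy does, so the expectation rests on the ethoxy result alone and carries extra uncertainty. For compound 4 the expected step is therefore a 6.0-fold lower number from compound 3 to compound 4 (0.78 log units; beyond the scatter), a lower dose. The estimate for compound 4 in this assay is 0.5 mg/kg, with a range from 0.1 mg/kg to 3 mg/kg.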

Compound 4, minimum effective dose: > 1 mg/kg
Compound 4 gave a limit, no number (the forecaster's own chance of this, stated with the estimate: 5%); middle value at least 2.0-fold (0.30 log units) away from the limit.
By their numbers in this assay, from the lowest: compound 1; then compound 2; then compound 3.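

In this assay compound 4 gives > 1 mg/kg, which is a limit and not a number. Even so, the length of the alkoxy chain matters at this position, and not only the kind of group attached to the ring: shortening ethoxy to methoxy gives an at least 3.3-fold higher number from compound 2 to compound 4 (0.52 log units; beyond the scatter), and the larger change from propylsulfanyl to methoxy gives an at least 10-fold higher number from compound 1 to compound 4 (1.00 log units; beyond the scatter). From the compounds shown here alone, the step from propyl to methoxy cannot be read, so the order of these two compounds stays unknown.

Going by these compounds, it remains open whether a longer alkoxy group such as propoxy would need a still smaller dose than ethoxy, and how it would compare with propylsulfanyl. Also open, on these data alone, is how a nitrogen-linked chain such as propylamino would behave at this position.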